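A few compounds are considered here, and "the series" means these few. Any claim that something is new, unique, unknown or untested is made for them only; others in the source may bear on it.

Of the compounds shown here, three that share one core have so far been tested in an ADME assay on NIH3T3 cells (Mus musculus) for cytotoxicity, read by XTT assay, with a stated time of 24 h; a lower number here means a stronger inhibitor, a higher number a weaker inhibitor. Compound 1 `Fc1ccc(C2CC(c3ccc(Cl)s3)=NN2c2nc(-c3ccc(Cl)cc3)cs2)cc1` returns only a limit of that assay, > 500 ug/mL. Compound 3 `N#Cc1ccc(-c2csc(N3N=C(c4ccc(Cl)s4)CC3c3ccc(F)cc3)n2)cc1`, which carries a cyano in place of chloro on an aromatic carbon, also returns only a limit, > 500 ug/mL. The step that the two limits leave unreadable from compound 1 to compound 3 therefore cannot be read, because both of its ends sit at the limit of > 500 ug/mL in this assay, at which 2 of the 3 values shown sit. Within the data shown here, compound 2 `Cc1ccc(C2=NN(c3nc(-c4ccc([N+](=O)[O-])cc4)cs3)C(c3ccc(F)cc3)C2)s1` stands apart as the single compound with an actual number: in this assay compound 2 gives 15.6 ug/mL, and so it is the only measured point from which any further step can be followed.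

Compound 4 `Cc1ccc(C2=NN(c3nc(-c4ccc(C(F)(F)F)cc4)cs3)C(c3ccc(F)cc3)C2)s1` differs from compound 2 by trifluoromethyl in place of nitro on an aromatic carbon. Among the measured compounds shown here, no measured step bears directly on this change, and the one step that was measured, a step that the two limits leave unreadable from compound 1 to compound 3, is itself unreadable. The expectation for compound 4 thus rests on compound 2 alone, tempered by the fact that two of the three measured compounds reached (the limit of > 500 ug/mL in this assay, at which 2 of the 3 values shown sit). Compound 4 is expected to show a step of a 3.8-fold higher number from compound 2 to compound 4 (0.59 log units; beyond the scatter) toward weaker inhibition, with a real chance of another limit. Compound 4 is estimated at 60 ug/mL, within a range from 10 ug/mL to 500 ug/mL.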

Compound 4, half-maximal inhibitory concentration: > 500 ug/mL
Compound 4 gave a limit, no number; the forecaster's own chance of this, stated with the estimate: 35%; middle value at least 8.3-fold (0.92 log units) from the limit.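

In this assay the series now has its first step that can be read, and it is large: an at least 32-fold higher number from compound 2 to compound 4 (1.50 log units; beyond the scatter) as 4-nitrophenyl gives way to 4-(trifluoromethyl)phenyl. This position, on an aromatic carbon of a six-membered aromatic ring of carbon only and para to a large group, is therefore not indifferent to what it carries, since this one exchange, with the rest of the structure unchanged, separates a measured number from a limit. Among these compounds, the step between compound 1 and compound 3 still cannot be read, compound 2 remains the only compound with an actual number, and the other values all stand at one limit: the limit of > 500 ug/mL in this assay, at which 3 of the 4 values shown sit.

As far as these compounds go, compound 4 returns only a limit, so the true size of its step stays open. These compounds cannot tell whether a number in this assay depends on nitro itself, or what an amine or a carboxylic acid at this same position would give on the scaffold of compound 2.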